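The compounds below may be only part of what the source reports. "The series", "measured", "known", "first", "only" and "open" are said of these compounds alone.

Three compounds have been measured so far in an ADME assay on HepG2 cells (Homo sapiens) for cytotoxicity, read by luminescence, CellTiter-Glo and ATP content, with a stated time of 72 h; a lower number here means that less compound is needed, a higher number that more compound is needed for the effect:

Compound 1, `COc1cccc(CNCCCNc2ccnc3cc(C4CCCCC4)ccc23)c1O`, gives 1080 nM.
Compound 2, `COc1ccc(F)cc1CNCCCNc1ccnc2cc(C3CCCCC3)ccc12`, gives 2290 nM.
Compound 3, `c1coc(CNCCCNc2ccnc3cc(C4CCCCC4)ccc23)c1`, gives 4760 nM.

Compound 1 has the lowest number of the three. Its nearest neighbour is compound 2, with a 2.1-fold higher number from compound 1 to compound 2 (0.33 log units; beyond the scatter). Furthest away is compound 3, with a 4.4-fold higher number from compound 1 to compound 3 (0.64 log units; beyond the scatter). Between the other two there is a 2.1-fold higher number from compound 2 to compound 3 (0.32 log units; beyond the scatter). All three measured steps change the group carried on a saturated chain carbon bound to an amine nitrogen, and every one of them is modest in size.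

The next compound, compound 4, `COc1cccc(CNCCCNc2ccnc3cc(-c4cccc5ccccc45)ccc23)c1O`, changes a different part of the molecule: naphthalen-1-yl in place of cyclohexyl on an aromatic carbon. Within the data shown here, none of the measured steps touches this place, so they offer no direct guide to how the number in this assay will move when the ring on the shared core is exchanged. Among the measured compounds shown here, with no comparable step to lean on, the expectation rests on compound 1 alone: the number for compound 4 is expected to stay close to that of compound 1, amounting to a 1.4-fold higher number from compound 1 to compound 4 (0.14 log units; within the scatter), with a wide margin either way. Compound 4 is estimated at 1500 nM, somewhere between 400 nM and 6000 nM.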

Compound 4, half-maximal effective concentration: 2520 nM
Compound 4: middle estimate off by 1.7-fold (0.23 log units), on the low side; the measured number falls inside the stated range.
By their numbers in this assay, from the lowest: compound 1; then compounds 2, 4 and 3 (each within the scatter of the next, the first and the last beyond it).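

Among these compounds, this is the first view of the ring on the shared core: exchanging cyclohexyl for naphthalen-1-yl on this aromatic carbon gives a 2.3-fold higher number from compound 1 to compound 4 (0.37 log units; beyond the scatter) in this assay. The group on the chain stays 2-hydroxy-3-methoxyphenyl throughout this step, so the change in the number belongs to this position alone, and the position is shown to influence the read-out, by a modest amount. The exchange replaces one non-aromatic ring of carbon with two aromatic rings and adds heavy atoms at the same time, and no measurement here separates those two changes or accounts for the higher number.

A single step cannot show whether ring size or aromatic character matters more at this carbon, and phenyl, cyclopentyl, an amine or a carboxylic acid in this place would begin to tell those possibilities apart. From the compounds shown here alone, it also remains open whether naphthalen-1-yl would produce a step of similar size in compounds carrying furan-2-yl or 5-fluoro-2-methoxyphenyl on the chain.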